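Dichlorophenyl in Place of Phenyl on a Lipoyl-Coumarin Conjugate

The source may report more compounds than this note shows. Statements on the series, on what has been measured and on what is new or still open speak of the compounds shown alone.

Measured compounds:
- compound 1, `O=C(CCCCC1CCSS1)NCc1cn(CCCOc2ccc3cc(-c4ccc(Br)cc4)c(=O)oc3c2)nn1`: 57.3%
- compound 2, `O=C(CCCCC1CCSS1)NCc1cn(CCCCOc2ccc3cc(-c4ccccc4)c(=O)oc3c2)nn1`: 32.8%

Both compounds were tested in a functional assay on PC-12 cells (Rattus norvegicus) for cytotoxicity, read by MTT assay, with stated times of 3 h and 2 h, tested at 5 uM; a lower number here means a weaker effect, a higher number a stronger effect of the compound at the concentration tested. Compound 1 gives 57.3% in this assay, and compound 2 gives 32.8%, the lower of the two numbers, a gap beyond the usual scatter. For the measured compounds named here, the two compounds differ in more than one place, so no single step between them is set out; only what their two values show can be taken from them.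

Compound 3, `O=C(CCCCC1CCSS1)NCc1cn(CCCCOc2ccc3cc(-c4ccc(Cl)c(Cl)c4)c(=O)oc3c2)nn1`, is not yet measured. It differs from compound 2 in one place: 3,4-dichlorophenyl in place of phenyl on an aromatic carbon. Going by the values given here, the only halogenated analogue seen here, compound 1, gives the higher number, but it also carries a different chain, so that number gives only a loose hint. A step upward from compound 2 of moderate size is expected, though one within the scatter would not surprise.

Compound 3 is estimated at 45% in this assay, within 28% to 62%, which means an expected step of a number 12.2 percentage points higher from compound 2 to compound 3 (beyond the scatter).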

Compound 3, a percentage reported as activity, at one concentration (the size of the read-out at that concentration, not a potency): 53.2%
Beside the measured number, compound 3's estimate is 8.2 percentage points below it, and the stated range covers the measured number.
By their numbers in this assay, from the lowest: compound 2; then compounds 3 and 1 (each within the scatter of the next).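

In this assay, for the compounds shown here, the change from phenyl to 3,4-dichlorophenyl gives a number 20.4 percentage points higher from compound 2 to compound 3 (beyond the scatter) as the first single-change step at this position on the core. Compound 1 differs from compound 2 in more than one place, so its higher number could not be tied to one group, whereas this step isolates the change of aryl group while the chain stays the same. Nothing measured here explains why the number rises.

From the compounds shown here alone, it remains open whether a single chlorine, a methoxy group or an amine on this phenyl ring would give a step of similar size, and whether the same change would have a similar effect on the chain carried by compound 1. These readings also come from one concentration, so they show the size of the effect at that concentration and leave open how the compounds would compare across a range of concentrations.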